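The compounds below may be only part of what the source reports. "The series", "measured", "known", "first", "only" and "open" are said of these compounds alone.

Compound 1 `Cc1cc(NC(=O)Cn2nnc(-c3ccccc3)n2)n(C2CCCCC2)n1`: 187 mL/min/kg
Compound 2 `Cc1cc(NC(=O)Cn2nnc(-c3ccccc3)n2)n(C2CCS(=O)(=O)C2)n1`: < 23.1 mL/min/kg (a limit)
Compound 3 `Cc1cc(NC(=O)Cn2nnc(-c3ccccc3)n2)n(CC2CCCCC2)n1`: 753 mL/min/kg

In an ADME assay on microsomes from liver (Homo sapiens) for metabolic stability (a higher number here means faster removal of the compound, a lower number slower removal), compound 1 gives 187 mL/min/kg, the lower of the two exact numbers in this small set. Compound 3 stands above it, and the reading for compound 2 is only a limit.

Compound 4 `Cc1cc(NC(=O)Cn2nnc(-c3cccc(F)c3)n2)n(C2CCCCC2)n1` keeps the rest of compound 1 and turns its phenyl into 3-fluorophenyl: fluoro in place of hydrogen on an aromatic carbon. Among the compounds with values here, no measured step touches that ring. All three instead exchange the group on an aromatic nitrogen: an at least 8.0-fold lower number from compound 1 to compound 2 (0.90 log units; beyond the scatter), a 4.0-fold higher number from compound 1 to compound 3 (0.60 log units; beyond the scatter) and an at least 32-fold higher number from compound 2 to compound 3 (1.51 log units; beyond the scatter). These steps show how far the numbers move with that group, but they give no size for fluoro in place of hydrogen on an aromatic carbon. No step beyond the scatter is therefore expected for compound 4, starting from compound 1 at 187 mL/min/kg, and no direction is favoured. The expected step is a 1.0-fold lower number from compound 1 to compound 4 (0.02 log units; within the scatter). For compound 4 the estimated value is 180 mL/min/kg, with an expected range from 90 mL/min/kg to 350 mL/min/kg.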

Compound 4, clearance: 162 mL/min/kg
Estimate against measurement, compound 4: 1.1-fold (0.05 log units) above; the measured number falls inside the stated range.
By their numbers in this assay, from the lowest: compounds 4 and 1 (each within the scatter of the next); then compound 3. At a limit, below all of these: compound 2.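

Until compound 4, every measured step had exchanged the group on an aromatic nitrogen. This one, in this assay, falls on an aromatic carbon of the six-membered aromatic ring of carbon only, meta to a large group, and gives a 1.2-fold lower number from compound 1 to compound 4 (0.06 log units; within the scatter). The change from phenyl to 3-fluorophenyl therefore leaves the clearance within the scatter, unlike each of the exchanges on the aromatic nitrogen, and nothing given here offers a cause for this outcome.

On these data alone, what chloro, methoxy or a nitrile would do at this place on the ring remains open, as does the effect of fluoro elsewhere on it. As far as these compounds go, it is also open whether 3-fluorophenyl would behave the same alongside cyclohexylmethyl or 1,1-dioxothiolan-3-yl in place of cyclohexyl.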